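From 3-bromophenyl to 2-methoxyphenyl on the shared core

The compounds below may be only part of what the source reports. "The series", "measured", "known", "first", "only" and "open" are said of these compounds alone.

Compound 1 `O=C(NCc1cccc(Br)c1)N1C(=O)c2ccccc2S1(=O)=O` is the starting point in a physicochemical assay for pharmacokinetics (a lower number here means that the compound disappears faster, a higher number that the compound lasts longer), and has no exact reading there. Compound 1 gives > 166 h as its half-life, which is a limit and not a number. Compound 2 `O=C(Oc1ccccc1)N1C(=O)c2ccccc2S1(=O)=O` gives > 3.04 h as its half-life, also a limit. Neither compound has an exact number, so the two cannot be ranked.

Compound 3 `COc1ccccc1CNC(=O)N1C(=O)c2ccccc2S1(=O)=O` carries 2-methoxyphenyl in place of 3-bromophenyl on a saturated chain carbon bound to an amide-type nitrogen. Going by the values given here, no measured pair shows what a change at this place does. The expectation therefore rests on compound 1 alone, whose > 166 h is a limit. The expected shift an at least 1.1-fold lower number from compound 1 to compound 3 (0.04 log units; that floor lies within the scatter) has no clear direction and stays within the usual scatter. Compound 3 is estimated at 150 h with an expected range from 40 h to 600 h for its half-life.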

Compound 3, half-life: > 166 h
Compound 3: no number, only a limit; the forecaster's own chance of this, stated with the estimate: 50%; at least 1.1-fold (0.04 log units) between middle value and limit.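

In this assay compound 3 gives > 166 h as its half-life, a limit and not a number. Going by these compounds alone, no step from compound 1 to compound 3 can be read, because both stop at one limit: the limit of > 166 h in this assay, at which 2 of the 3 values shown sit.

As far as these compounds go, whether 2-methoxyphenyl in place of 3-bromophenyl shifts the half-life in either direction stays open.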